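Methoxy Added to a Small Lactone Core

The source may report more compounds than this note shows. Statements on the series, on what has been measured and on what is new or still open speak of the compounds shown alone.

Compound 1 `COc1ccc2cc(CCCO)oc(=O)c2c1` gives 28.9 ug/mL in a functional assay on U-251 cells (Homo sapiens) for antiproliferative activity, read by sulforhodamine B assay, with a stated time of 48 h; a higher number here means a weaker inhibitor of growth, a lower number a stronger inhibitor of growth.
Compound 2 `O=C1OC(CO)Cc2ccccc21` gives >= 250 ug/mL in this assay, which is a limit of the assay and not a number.

Compound 2 thus stands at the limit of >= 250 ug/mL in this assay, at which 1 of the 2 values shown sits, while compound 1 shows a number well inside the measurable range. Compound 3 `COc1ccc2c(c1)C(=O)OC(CO)C2` differs from compound 2 by methoxy in place of hydrogen on an aromatic carbon, in words methoxy in place of hydrogen on an aromatic carbon. For the measured compounds named here, no measured pair isolates this single change, so the step expected here is a number no higher from compound 2 to compound 3 (the limit leaves the size open), with no direction beyond the usual scatter. Compound 3 is therefore expected to give 250 ug/mL in this assay, between 100 ug/mL and 400 ug/mL, most likely reported again only as a limit.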

Compound 3, concentration for 50% growth inhibition: >= 250 ug/mL
Compound 3: a limit, no number; the forecaster's own chance of this, stated with the estimate: 70%; the middle value sits exactly at the limit.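

Compound 2 and compound 3 both stop at a limit of the assay, not a number, so no step can be read between them: the limit of >= 250 ug/mL in this assay, at which 2 of the 3 values shown sit.

Going by these compounds, whether methoxy in place of hydrogen on an aromatic carbon changes growth inhibition at all remains open.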